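Restoring an alkyl on the amide nitrogen of compound 3

The source may report more compounds than this note shows. Statements on the series, on what has been measured and on what is new or still open speak of the compounds shown alone.

Measured so far:
compound 1 `CCN(Cc1cccs1)C(=O)COc1ccc(C(C)C)cc1`: 397 nM
compound 2 `Cc1ccc(OCC(=O)N(Cc2cccs2)c2ccnn2C)cc1`: 422 nM
compound 3 `Cc1ccc(OCC(=O)N(O)Cc2cccs2)cc1`: 8000 nM

Among the measured compounds shown here, in an assay on HEK293 cells for agonist activity at transient receptor potential cation channel subfamily M member 8 (Homo sapiens), read by fluorescence and calcium flux, with a stated time of 15 min (a lower number here means that less compound is needed, a higher number that more compound is needed for the effect), compound 3 gives the highest number of the three; the one measured step onto it is a 19-fold higher number from compound 2 to compound 3 (1.28 log units; beyond the scatter), and the value of compound 3 sits a similar distance from compound 1. The change from compound 3 to compound 4 `CCN(Cc1cccs1)C(=O)COc1ccc(C)cc1` is ethyl in place of hydroxy on an amide-type nitrogen. For the measured compounds named here, the single measured step that bears on this place, the one from compound 2 to compound 3, was large and ran toward a higher number when a hydroxy entered; compound 1 carries an ethyl on the same nitrogen and gives 397 nM. Compound 4 is therefore expected to move back toward the lower numbers, with an estimated step of a 16-fold lower number from compound 3 to compound 4 (1.20 log units; beyond the scatter). For compound 4 the estimate is 500 nM, in the range 150 nM to 1600 nM.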

Compound 4, half-maximal effective concentration: 8 nM
Compound 4: middle estimate off by 63-fold (1.80 log units), on the high side; the whole stated range lies above it.
By their numbers in this assay, from the lowest: compound 4; then compounds 1 and 2 (each within the scatter of the next); then compound 3.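

In this assay, ethyl on the amide-type nitrogen gives a 1000-fold lower number from compound 3 to compound 4 (3.00 log units; beyond the scatter) when it replaces hydroxy and a 53-fold lower number from compound 2 to compound 4 (1.72 log units; beyond the scatter) when it replaces 1-methyl-1H-pyrazol-5-yl, so ethyl is far ahead of both other groups at this place. The earlier compounds shown here did not show that the group on the aromatic carbon also counts: methyl in place of isopropyl gives a 50-fold lower number from compound 1 to compound 4 (1.70 log units; beyond the scatter) with ethyl on the nitrogen. Nothing here explains why either change has so large an effect. On these data alone, whether a methyl or a propyl on the nitrogen would do as well as ethyl remains open, as does the effect of a chlorine or a methoxy on the aromatic carbon.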